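Aryloxy exchange on the shared core: compound 2 to compound 3

The source may report more compounds than this note shows. Statements on the series, on what has been measured and on what is new or still open speak of the compounds shown alone.

Measured so far:
compound 1 `CC(C)CCn1ccc(-c2ccc(OC3CCCC3)c(Cl)c2)c(C#N)c1=O` — 100 nM
compound 2 `CC(C)CCn1ccc(-c2ccc(Oc3ccccc3)cc2)c(C#N)c1=O` — 42 nM

In a functional assay on CHO cells for positive allosteric modulation of metabotropic glutamate receptor 2 (Homo sapiens), read by scintillation counting and GTPgammaS binding, with a stated time of 30 min (on this read-out lower numbers stand for an effect already at smaller amounts and higher numbers for an effect only at larger amounts of compound), compound 2 gives 42 nM, the lowest of the two numbers recorded; compound 1 sits at a higher number, and the gap between the two lies beyond the scatter. Within the data shown here, no single-point step between measured compounds is available, so the two values show only that the two aryloxy partners on the shared core land apart.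

Compound 3 `Cc1ccc(Oc2ccc(-c3ccn(CCC(C)C)c(=O)c3C#N)cc2)c(C)n1` differs from compound 2 by 2,6-dimethylpyridin-3-yl in place of phenyl on an oxygen on an aromatic ring. Among the measured compounds shown here, no measured pair covers this exchange, and the direction of its effect cannot be read from compound 1, which changes several features at once. The step of a 1.5-fold higher number from compound 2 to compound 3 (0.19 log units; within the scatter) is therefore expected to be modest, either within the scatter or a small move to higher numbers. Compound 3 is expected at 65 nM, in the range 25 nM to 170 nM.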

Compound 3, half-maximal effective concentration: 100 nM
Compound 3: the middle estimate sits 1.5-fold (0.19 log units) below what was measured; measured number inside the range.
By their numbers in this assay, from the lowest: compound 2; then compounds 1 and 3 (each within the scatter of the next).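

In this assay, among these compounds, the exchange of phenyl for 2,6-dimethylpyridin-3-yl on an oxygen on an aromatic ring gives a 2.4-fold higher number from compound 2 to compound 3 (0.38 log units; beyond the scatter) as the first single-place step. This position therefore responds to the exchange, and of this pair the plain phenyl holds the lower number, while the entering ring with its hydrogen-bond acceptor still gives a measurable effect. Nothing measured on hand bears on why the number moves.

Open, as far as these compounds go, is how the step divides between the ring nitrogen and the two methyl groups, which a pyridine ring without the methyl groups or a phenyl ring carrying both of them would separate. Also open, from the compounds shown here alone, is how this position responds to a ring bearing an amine or a carboxylic acid.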